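From Phenyl to 3-Chlorophenyl on the Shared Core

The source may report more compounds than this note shows. Statements on the series, on what has been measured and on what is new or still open speak of the compounds shown alone.

In a functional assay on SK-OV-3 cells (Homo sapiens) for antiproliferative activity, read by MTT assay, with a stated time of 24 h (a lower number here means a stronger inhibitor, a higher number a weaker inhibitor), compound 3 (`COc1ccc(C(=O)/C=C/c2ccccc2)c2c1C=CC(C)(C)O2`) is recorded at > 10000 nM as a limit of the assay, not a number. Compound 1 (`COc1ccc(/C=C/C(=O)c2ccc(OC)c3c2OC(C)(C)C=C3)c(F)c1`) gives 4880 nM and compound 2 (`COc1ccc(C(=O)/C=C/c2ccc(N(C)C)cc2)c2c1C=CC(C)(C)O2`) gives 2750 nM on the same scale. Compound 4 (`COc1ccc(C(=O)/C=C/c2cccc(Cl)c2)c2c1C=CC(C)(C)O2`) differs from compound 3 by chloro in place of hydrogen on an aromatic carbon in one place: chloro in place of hydrogen on an aromatic carbon, meta to a large group. The steps of an at least 2.0-fold higher number from compound 1 to compound 3 (0.31 log units; beyond the scatter) and an at least 3.6-fold higher number from compound 2 to compound 3 (0.56 log units; beyond the scatter) put plain phenyl on the higher-number side of two substituted rings, neither with chloro, so a modest drop is expected for compound 4 in this assay. The estimated step is an at least 1.6-fold lower number from compound 3 to compound 4 (0.22 log units; that floor lies within the scatter) as a rough guide. The expected value for compound 4 is 6000 nM and runs from 2500 nM to 12000 nM in this estimate.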

Compound 4, half-maximal inhibitory concentration: > 10000 nM
Compound 4 gave a limit, no number (the forecaster's own chance of this, stated with the estimate: 35%); middle value at least 1.6-fold (0.22 log units) away from the limit.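

In this assay, chloro on the phenyl ring of compound 3, on an aromatic carbon meta to a large group, yields no measured number: compound 4 is also recorded as a limit, and the step between these two limits cannot be read. The 3-chlorophenyl compound stays on the higher-number side of both substituted rings, with an at least 3.6-fold higher number from compound 2 to compound 4 (0.56 log units; beyond the scatter) and an at least 2.0-fold higher number from compound 1 to compound 4 (0.31 log units; beyond the scatter). Any effect of chloro here stays hidden at one shared limit: the limit of > 10000 nM in this assay, at which 2 of the 4 values shown sit.

As far as these compounds go, whether chloro moves the result at all remains open. So does whether a nitrile or a carboxylic acid in the same place would give a measured number.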